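This account rests on a few compounds, and the source may have more. Where it says the series, first, only, none or still open, it means among the compounds named here.

In an ADME assay on microsomes from liver (Mus musculus) for metabolic stability, tested at 5 uM (a higher number here means that the compound lasts longer, a lower number that the compound disappears faster), compound 1 (`CCCCNc1ccc([N+](=O)[O-])cc1S(N)(=O)=O`) gives 0.1 h as its half-life. Compound 3 (`CCCCCCCCNc1ccc(C(=O)O)cc1S(=O)(=O)NC`) gives 0.2 h in the same measurement and carries carboxy on the shared core. Compound 2 (`CCCCCCNc1ccc([N+](=O)[O-])cc1S(=O)(=O)N(C)C`) reads < 0.0834 h as a limit of the assay and not as a number. Compound 2 thus stands at the limit of < 0.0834 h in this assay, at which 1 of the 3 values shown sits, and gives no exact starting point for what follows.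

Compound 4 (`CCCCCCNc1ccc(C(=O)O)cc1S(=O)(=O)N(C)C`) keeps the hexylamino and dimethylsulfamoyl groups of compound 2. It has carboxy in place of nitro on an aromatic carbon, meta to the dimethylsulfamoyl group and para to the hexylamino group.

Among the measured compounds shown here, no two measured compounds differ in one place only, so the size of this change has not been measured directly. The nearest guide is compound 3 at 0.2 h as its half-life, although it also differs from compound 4 elsewhere. On that guide a modest upward step is expected (an at least 2.0-fold higher number from compound 2 to compound 4 (0.30 log units; that floor lies within the scatter)), and compound 4 could still return only a limit. The estimated half-life of compound 4 is 0.17 h with an expected range from 0.09 h to 0.4 h in this assay when it is measured.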

Compound 4, half-life: 0.283 h
Compound 4: middle estimate off by 1.7-fold (0.22 log units), on the low side; the measured number falls inside the stated range.
By their numbers in this assay, from the lowest: compounds 1, 3 and 4 (each within the scatter of the next, the first and the last beyond it). At a limit, below all of these: compound 2.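

Among the compounds shown here, this pair gives the first direct reading of one change on the shared core: on the aromatic carbon para to a hexylamino group and meta to a dimethylsulfamoyl group, replacing nitro with carboxy in this assay gives an at least 3.3-fold higher number from compound 2 to compound 4 (0.53 log units; beyond the scatter). The two groups hold the same number of heavy atoms and neither brings a ring, but carboxy has carbon where nitro has nitrogen and adds a hydrogen-bond donor, so a swap of this kind at this position can move the half-life beyond the usual scatter. The step is only a floor and its true size stays unknown because compound 2 gives a limit and not a number: the limit of < 0.0834 h in this assay, at which 1 of the 4 values shown sits.

From the compounds shown here alone, whether the gain is specific to carboxy remains open, since a nitrile or a primary amide on the same aromatic carbon would show whether other replacements for nitro give a similar step. It is also unclear whether the step would keep its size with a longer chain in place of hexylamino, or with a different group in place of dimethylsulfamoyl.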